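This account rests on a few compounds, and the source may have more. Where it says the series, first, only, none or still open, it means among the compounds named here.

Values so far in a functional assay on SGC-7901 cells (Homo sapiens) for cytotoxicity, read by MTT assay, with a stated time of 48 h; on this read-out lower numbers stand for stronger inhibition and higher numbers for weaker inhibition:

- compound 1 `Cc1ncc([N+](=O)[O-])n1CCSc1nnc(-c2ccccc2)o1` gives 30100 nM
- compound 2 `Cc1ncc([N+](=O)[O-])n1CCSc1nnc(-c2ccc([N+](=O)[O-])cc2)o1` gives 12200 nM
- compound 3 `Cc1ncc([N+](=O)[O-])n1CCSc1nnc(-c2ccccc2Cl)o1` gives 32600 nM

In this assay, compound 3 at 32600 nM sits within the scatter of compound 1 at 30100 nM, and both numbers are higher than that of compound 2 at 12200 nM.

Next is compound 4 `Cc1ncc([N+](=O)[O-])n1CCSc1nnc(-c2ccc(Cl)cc2)o1`, with 4-chlorophenyl in place of 2-chlorophenyl on an aromatic carbon.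

For the measured compounds named here, two measured steps bear on this. Adding chloro gave a 1.1-fold higher number from compound 1 to compound 3 (0.03 log units; within the scatter), and adding nitro gave a 2.5-fold lower number from compound 1 to compound 2 (0.39 log units; beyond the scatter), a modest change. Going by the values given here, no measured pair moves a group from one place to another, so the data give no direct size for this change. With compound 3 at 32600 nM as the starting point, little movement is expected.

The expected change is a 1.3-fold lower number from compound 3 to compound 4 (0.10 log units; within the scatter), which would be no real step beyond the scatter.

For compound 4 the estimated value is 26000 nM, with an expected range of 12000 nM to 50000 nM.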

Compound 4, half-maximal inhibitory concentration: 31900 nM
Estimate against measurement, compound 4: 1.2-fold (0.09 log units) below, and the stated range covers the measured number.
By their numbers in this assay, from the lowest: compound 2; then compounds 1, 4 and 3 (each within the scatter of the next).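

In this assay, moving the chloro from 2-chlorophenyl to 4-chlorophenyl gives a 1.0-fold lower number from compound 3 to compound 4 (0.01 log units; within the scatter), so the series now has a direct reading of chloro placement on this ring, and that change does not separate the two compounds. Chloro in place of hydrogen also stays flat with this new placement, at a 1.1-fold higher number from compound 1 to compound 4 (0.03 log units; within the scatter), whereas chloro in place of nitro gives a 2.6-fold higher number from compound 2 to compound 4 (0.42 log units; beyond the scatter), so among the compounds shown only the nitro compound stands apart. The data offer no measured property that accounts for any of these steps.

Open, on these data alone, is whether an amine or a carboxylic acid on the phenyl ring would stay with hydrogen and chloro or stand apart as nitro does. Also open, as far as these compounds go, is how a longer chain linking the two halves of the shared core would read here.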